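Bromo in place of hydrogen on compound 3

The compounds below may be only part of what the source reports. "The series", "measured", "known", "first", "only" and "open" are said of these compounds alone.

Compound 1 `COc1ccc2cc1Oc1ccc(cc1)C1OC1COC(=O)CC2`, compound 2 `COc1ccc2cc1Oc1ccc(cc1)CC(I)COC(=O)CC2` and compound 3 `COc1ccc2cc1Oc1ccc(cc1)CC(O)COC(=O)CC2` share one core. In a functional assay on 1A9 cells (Homo sapiens) for inhibition (a higher number here means a weaker inhibitor, a lower number a stronger inhibitor), compound 1 gives > 2500 nM, which is a limit. Compound 2 gives > 2500 nM, also a limit. Compound 3 gives > 2500 nM, again a limit. Among the compounds with values here, the series so far stands at the limit of > 2500 nM in this assay, at which 3 of the 3 values shown sit.

Compound 4 `COc1c(Br)cc2cc1Oc1ccc(cc1)CC(O)COC(=O)CC2` follows from compound 3 through (bromo in place of hydrogen on an aromatic carbon). Within the data shown here, the one measured step, a step that the two limits leave unreadable from compound 2 to compound 3, concerns a saturated ring carbon rather than an aromatic one and sets no size for this change. Among the measured compounds shown here, no measured compound carries a bromo group, so no direction is expected with any confidence.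

The estimate amounts to a step that the limit leaves unreadable from compound 3 to compound 4, expected to show no clear change. For compound 4 the expected value in this assay is 3000 nM, with an estimated range from 1000 nM to 10000 nM.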

Compound 4, half-maximal inhibitory concentration: > 2500 nM
Compound 4 gave a limit, no number (the forecaster's own chance of this, stated with the estimate: 75%); the middle value is on the limit's open side.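

No step can be read from compound 3 to compound 4, as both sit at a limit in this assay: the limit of > 2500 nM in this assay, at which 4 of the 4 values shown sit.

The compounds shown leave open which change to the shared core, if any, would give a value short of that limit.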